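Hydroxymethyl in place of (propylamino)methyl on the shared core

This account rests on a few compounds, and the source may have more. Where it says the series, first, only, none or still open, it means among the compounds named here.

Compound 1 `CCCNC(=O)C1CCN(C(=O)c2cc3sccc3n2Cc2ccc(OC)cc2)CC1` carries a hydrogen on the aromatic carbon that the later analogues substitute; in an ADME assay on HEK-293T cells (Homo sapiens) for cytotoxicity, read by luminescence, with a stated time of 24 h (a lower number here means that less compound is tolerated, a higher number that more compound is tolerated), compound 1 gives 18800 nM. Compound 2 `CCCNC(=O)C1CCN(C(=O)c2cc3sc(C(=O)c4ccccc4)cc3n2Cc2ccc(OC)cc2)CC1` places a benzoyl there, and in this assay compound 2 reaches only a limit of the assay, > 100000 nM. Compound 3 `CCCNCc1cc2c(cc(C(=O)N3CCC(C(=O)NCCC)CC3)n2Cc2ccc(OC)cc2)s1` carries (propylamino)methyl at the same carbon; in this assay compound 3 likewise gives only a limit, > 100000 nM. The two substitutions read as an at least 5.3-fold higher number from compound 1 to compound 2 (0.72 log units; beyond the scatter) and an at least 5.3-fold higher number from compound 1 to compound 3 (0.72 log units; beyond the scatter), so compound 3 stands with compound 2 at the high end of the three values, with no number of its own, because the limit of > 100000 nM in this assay, at which 2 of the 3 values shown sit, covers both. The step between compound 2 and compound 3, a step that the two limits leave unreadable from compound 2 to compound 3, cannot be sized.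

Compound 4 `CCCNC(=O)C1CCN(C(=O)c2cc3sc(CO)cc3n2Cc2ccc(OC)cc2)CC1` is compound 3 with hydroxy in place of propylamino on a saturated chain carbon bound to an aromatic carbon. Among the compounds with values here, no measured step changes this group; the steps that bear on the position are those from compound 1, which both ran to the limit. A hydroxymethyl at that carbon is therefore expected to keep the number near the limit, and the step of an at least 1.2-fold lower number from compound 3 to compound 4 (0.09 log units; that floor lies within the scatter) is estimated to stay within the scatter, with a real chance that only a limit is again reported. Compound 4 is expected to give about 80000 nM in this assay, between 20000 nM and 150000 nM.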

Compound 4, half-maximal cytotoxic concentration: 15500 nM
The estimate for compound 4 lay 5.2-fold (0.71 log units) above the measured number; measured number below the stated range.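

Substitution at this aromatic carbon does not by itself move the number in this assay: with hydroxymethyl in place of hydrogen, the reading is a 1.2-fold lower number from compound 1 to compound 4 (0.08 log units; within the scatter). The identity of the group therefore counts among these compounds, as exchanging propylamino for hydroxy on the saturated chain carbon gives an at least 6.4-fold lower number from compound 3 to compound 4 (0.80 log units; beyond the scatter), and hydroxymethyl in place of benzoyl gives an at least 6.4-fold lower number from compound 2 to compound 4 (0.80 log units; beyond the scatter). Compound 2 and compound 3 remain tied to a limit of the assay, so these two steps are known only as floors and the step between compound 2 and compound 3 cannot be read: the limit of > 100000 nM in this assay, at which 2 of the 4 values shown sit.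

Going by these compounds, what separates (propylamino)methyl and benzoyl from hydroxymethyl remains open, since these groups differ in more than one feature and the two high readings are not numbers. An aminomethyl, a methoxymethyl or a plain butyl chain at the same carbon would show whether the nitrogen, the free hydroxy or the chain length goes with the change in this assay, and a carboxylic acid there would extend the comparison to a further group.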